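Hydroxy for Chloro on the Benzyl Group

This account rests on a few compounds, and the source may have more. Where it says the series, first, only, none or still open, it means among the compounds named here.

Measured in a functional assay on MGC-803 cells (Homo sapiens) for antiproliferative activity, read by MTT assay, with a stated time of 72 h (on this read-out lower numbers stand for stronger inhibition and higher numbers for weaker inhibition), so far:
Compound 1 `CCCSc1nc(N/N=C(\C)c2ccccc2O)c2nnn(Cc3ccc(Cl)cc3)c2n1`: 7100 nM
Compound 2 `CCCSc1nc(N/N=C(\C)c2ccc(OC)cc2)c2nnn(Cc3ccccc3)c2n1`: 44300 nM
Compound 3 `C#CCSc1nc(N/N=C(\C)c2ccccc2O)c2nnn(Cc3ccccc3)c2n1`: 3820 nM

Compound 1 stands second highest of these three numbers. Its nearest neighbour is compound 3, whose number lies within the usual scatter of compound 1, so the two cannot be ordered. Compound 2 is the furthest away, with a higher number that lies beyond the scatter. Compounds 1, 2 and 3 differ from one another in more than one place, so no single change can be read off between any two of them.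

Compound 4 `CCCSc1nc(N/N=C(\C)c2ccccc2O)c2nnn(Cc3ccc(O)cc3)c2n1` has not yet been measured. Against compound 1 it shows (hydroxy in place of chloro on an aromatic carbon). Among the compounds with values here, no measured pair carries this same exchange, so there is no direct precedent for its size or direction. The expectation is therefore a small step, most likely not beyond the scatter, if anything toward a slightly higher number. Compound 4 is expected at 9000 nM, with a range from 3500 nM to 25000 nM. That estimate corresponds to an expected step of a 1.3-fold higher number from compound 1 to compound 4 (0.10 log units; within the scatter).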

Compound 4, half-maximal inhibitory concentration: 7680 nM
For compound 4 the middle estimate is 1.2-fold (0.07 log units) above the measured one; the range from low to high includes it.
By their numbers in this assay, from the lowest: compounds 3, 1 and 4 (each within the scatter of the next); then compound 2.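

In this assay, within the data shown here, the exchange of chloro for hydroxy on the benzyl group gives a 1.1-fold higher number from compound 1 to compound 4 (0.03 log units; within the scatter) and this step lies within the usual scatter, so the first comparison in this set that differs in one place shows no change that can be read. At this aromatic carbon, para to a large group, the exchange adds a hydrogen-bond donor and a hydrogen-bond acceptor, yet the read-out does not separate 4-chlorobenzyl from 4-hydroxybenzyl. No outside evidence bears on this result.

The compounds shown leave open whether an amine or a carboxylic acid at this same place would also stay within the scatter of compound 1. They also leave open whether hydroxy in place of chloro reads the same when the compound carries a propargyl chain on sulfur instead of the propyl chain.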